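Adding a second chloro to the core of compound 3

A few compounds are considered here, and "the series" means these few. Any claim that something is new, unique, unknown or untested is made for them only; others in the source may bear on it.

Compound 1 `ClCc1ccccc1Cn1cnc2c(Cl)nc(Cl)nc21` and compound 2 `ClCc1ccccc1Cn1cnc2c(Cl)ncnc21` share a core and differ by one change, (chloro in place of hydrogen on an aromatic carbon). In a functional assay on BT-549 cells (Homo sapiens) for cytotoxicity, read by sulforhodamine B assay, with a stated time of 48 h (on this read-out lower numbers stand for higher toxicity in this test and higher numbers for lower toxicity in this test), compound 2 gives 20000 nM, while compound 1 gives 4160 nM, a step of a 4.8-fold lower number from compound 2 to compound 1 (0.68 log units; beyond the scatter). Compound 3 `ClCc1cccc(Cn2cnc3c(Cl)ncnc32)c1` is built from the same atoms as compound 2, joined differently; the difference between the two cores is not broken down here. In this assay compound 3 gives 60300 nM, the highest of the three numbers seen so far.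

Compound 4 `ClCc1cccc(Cn2cnc3c(Cl)nc(Cl)nc32)c1` has not yet been measured. It differs from compound 3 by chloro in place of hydrogen on an aromatic carbon, the same change that separates compound 2 from compound 1. Because that change gave a 4.8-fold lower number from compound 2 to compound 1 (0.68 log units; beyond the scatter), a step of similar size is expected from compound 3 to compound 4, a 4.0-fold lower number from compound 3 to compound 4 (0.60 log units; beyond the scatter), though this rests on a single measured pair. Compound 4 is therefore estimated at 15000 nM, likely between 6000 nM and 40000 nM.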

Compound 4, concentration lethal to 50% of the cells: 6160 nM
Compound 4: the middle estimate sits 2.4-fold (0.39 log units) above what was measured; measured number inside the range.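

In this assay, chloro in place of hydrogen on the aromatic carbon between two ring nitrogen atoms again lowers the number, with a 9.8-fold lower number from compound 3 to compound 4 (0.99 log units; beyond the scatter). Set beside the earlier pair, the two steps cannot be told apart: the same change on two cores in this assay, a 4.8-fold lower number (0.68 log units; beyond the scatter) from compound 2 to compound 1 and a 9.8-fold lower number (0.99 log units; beyond the scatter) from compound 3 to compound 4, 2.0-fold (0.31 log units) apart, within the scatter of two such steps. The change therefore carries over between these two cores in direction and, as far as repeat measurements can tell, in size, but two pairs are too few to show that it would hold on any other core, and they do not explain why the number falls.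

At this aromatic carbon the compounds shown carry only hydrogen or chloro, so it remains open how an amine, a methoxy group or a fluoro there would compare. From the compounds shown here alone, it also remains open whether the step would survive on a core where the chloromethyl group is replaced by a longer chain or a carboxylic acid.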